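Piperidine nitrogen capping groups in a GIP receptor agonist series

The compounds below may be only part of what the source reports. "The series", "measured", "known", "first", "only" and "open" are said of these compounds alone.

Measured compounds:
compound 1 `CCOC(=O)N1CCC(Oc2ncnc3c2CCN3c2ccc(S(C)(=O)=O)cc2F)CC1` – 251 nM
compound 2 `CC(C)SC(=O)N1CCC(Oc2ncnc3c2CCN3c2ccc(S(C)(=O)=O)cc2F)CC1` – 10 nM
compound 3 `CN(C)S(=O)(=O)N1CCC(Oc2ncnc3c2CCN3c2ccc(S(C)(=O)=O)cc2F)CC1` – 398 nM

In a functional assay on CHO-K1 cells for agonist activity at Glucose-dependent insulinotropic receptor (Homo sapiens), read by a luciferase reporter, with a stated time of 5 h (on this read-out lower numbers stand for an effect already at smaller amounts and higher numbers for an effect only at larger amounts of compound), compound 3 gives the highest number of the three. Its nearest neighbour is compound 1, with a 1.6-fold higher number from compound 1 to compound 3 (0.20 log units; within the scatter); its furthest is compound 2, with a 40-fold higher number from compound 2 to compound 3 (1.60 log units; beyond the scatter). Compound 4 `CN(C)C(=O)CN1CCC(Oc2ncnc3c2CCN3c2ccc(S(C)(=O)=O)cc2F)CC1` has not yet been measured. The change from compound 3 to compound 4 is (dimethylcarbamoyl)methyl in place of dimethylsulfamoyl on an amine nitrogen in a ring.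

Going by the values given here, no measured step covers this change. The steps that do exist all concern what sits on the same ring nitrogen: a 25-fold lower number from compound 1 to compound 2 (1.40 log units; beyond the scatter) shows that the capping group on this nitrogen can move the number a great deal, while a 1.6-fold higher number from compound 1 to compound 3 (0.20 log units; within the scatter) shows that some exchanges stay within the scatter. Among the compounds with values here, compound 4 is the only member of the group in which the ring nitrogen no longer carries a carbonyl or a sulfonyl but a (dimethylcarbamoyl)methyl chain, so the size of the effect is open in either direction. On the available numbers the expectation for compound 4 is a value near that of compound 3, with a wide range, i.e. an expected step of a 1.3-fold higher number from compound 3 to compound 4 (0.10 log units; within the scatter). The expected value of compound 4 in this assay is 500 nM, estimated to lie between 100 nM and 3000 nM.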

Compound 4, half-maximal effective concentration: > 10000 nM
Compound 4: only a limit was reported; the forecaster's own chance of this, stated with the estimate: 15%; middle value at least 20-fold (1.30 log units) from the limit.
By their numbers in this assay, from the lowest: compound 2; then compounds 1 and 3 (each within the scatter of the next). At a limit, above all of these: compound 4.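

Compound 4 is reported only as a limit, not as a number: the limit of > 10000 nM in this assay, at which 1 of the 4 values shown sits. This position therefore tolerates less than the earlier exchanges suggested, even though the leaving dimethylsulfamoyl and the entering (dimethylcarbamoyl)methyl have the same heavy-atom count, so that count alone does not separate the two caps: the change gives an at least 25-fold higher number from compound 3 to compound 4 (1.40 log units; beyond the scatter), and the comparisons with the other two caps give an at least 39-fold higher number from compound 1 to compound 4 (1.60 log units; beyond the scatter) and an at least 1000-fold higher number from compound 2 to compound 4 (3.00 log units; beyond the scatter). Among these four compounds, the three with a carbonyl or a sulfonyl on the amine nitrogen in a ring give measured values and the one with the (dimethylcarbamoyl)methyl chain does not, and no compound shown goes against this.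

The compounds shown do not separate the loss of a carbonyl or sulfonyl on this nitrogen from any contribution of the dimethylamide end of the new chain. A plain ethyl group on the ring nitrogen, and a dimethylcarbamoyl group placed on it without the intervening methyl link, would address these two possibilities separately.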